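Phenoxy-to-benzyl exchange on the aryl arm: compound 4

The source may hold more compounds than are shown below. What is called first, only, known or untested is meant among the compounds shown, and "the series" means these compounds.

Measured so far:
compound 1 `CCSc1nn2cc(-c3cc4ccccc4o3)nc2s1` — 2900 nM
compound 2 `COc1cc(OCc2cccc(COc3ccccc3)c2)c2cc(-c3cn4nc(OC)sc4n3)oc2c1` — 3.2 nM
compound 3 `CS(=O)(=O)c1nn2cc(-c3cc4ccccc4o3)nc2s1` — 820 nM

In a functional assay on HEK293 cells for antagonist activity at proteinase-activated receptor 4 (Homo sapiens), read by FLIPR and calcium flux, with a stated time of 30 min (on this read-out higher numbers stand for weaker inhibition and lower numbers for stronger inhibition), compound 2 gives the lowest of the three numbers, so the strongest inhibition measured here. Compound 3 sits nearest to it, and compound 1 furthest; both gaps are far beyond the scatter. Within the data shown here, the one single-point change measured so far is a 3.5-fold lower number from compound 1 to compound 3 (0.55 log units; beyond the scatter), a modest step on the small substituent of the shared core, not on the extended arm that distinguishes compound 2.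

Compound 4 `COc1cc(OCc2cccc(CCc3ccccc3)c2)c2cc(-c3cn4nc(OC)sc4n3)oc2c1` is the next member. It differs from compound 2 in one place: benzyl in place of phenoxy on a saturated chain carbon bound to an aromatic carbon. The same difference, cut one bond further out, reads phenoxymethyl to phenethyl.

Among the measured compounds shown here, no measured step touches this arm, so nothing bears directly on the exchange; the change keeps the atom count and the two rings in place. Without any step to lean on, the expectation for compound 4 is a number close to compound 2, a step of a 1.4-fold higher number from compound 2 to compound 4 (0.15 log units; within the scatter) that does not go beyond the scatter in either direction. In this assay compound 4 is therefore estimated at 4.5 nM, with a range from 1.5 nM to 14 nM.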

Compound 4, half-maximal inhibitory concentration: 2.4 nM
For compound 4 the middle estimate is 1.9-fold (0.27 log units) above the measured one, within the range that was stated.
By their numbers in this assay, from the lowest: compounds 4 and 2 (each within the scatter of the next); then compound 3; then compound 1.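

In this assay the exchange of phenoxy for benzyl on a saturated chain carbon bound to an aromatic carbon gives a 1.3-fold lower number from compound 2 to compound 4 (0.12 log units; within the scatter) and is the only step on the extended arm among the compounds shown. Compound 2 and compound 4 therefore cannot be told apart on this read-out, and on this pair the oxygen of the phenoxy, with the one hydrogen-bond acceptor counted for that group, can be replaced by carbon without a change beyond the scatter. Nothing at hand explains why the number holds across this exchange.

From the compounds shown here alone, the result covers one exchange on one pair, so it remains open how the number would respond to an amine or a carboxylic acid on the terminal ring of this arm, or to a longer chain in place of the benzyl. Going by these compounds, it also remains open whether the same exchange would again stay within the scatter on a core carrying ethylsulfanyl or methylsulfonyl in place of the methoxy of compound 2 and compound 4.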